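The source may hold more compounds than are shown below. What is called first, only, known or untested is meant among the compounds shown, and "the series" means these compounds.

Compound 3 `Cc1nc(-c2ccccc2)c(C(=O)N2CCN(c3ccccc3C(F)(F)F)CC2)o1` stands second highest of the three numbers in a functional assay on HL-60 cells (Homo sapiens) for inhibition, read by MTT assay, with a stated time of 72 h (on this read-out higher numbers stand for weaker inhibition and lower numbers for stronger inhibition), where compound 3 gives 120 nM. Compound 1 `Cc1nc(-c2ccccc2)c(C(=O)N2CCN(c3cccc(Cl)c3Cl)CC2)o1` gives 133 nM, and compound 2 `Cc1nc(-c2ccccc2)c(C(=O)N2CCN(c3ccc(C)c(C)c3)CC2)o1` gives 43 nM. The steps at this position are uneven: a 1.1-fold lower number from compound 1 to compound 3 (0.04 log units; within the scatter), whereas a 2.8-fold higher number from compound 2 to compound 3 (0.45 log units; beyond the scatter). Compound 4 `Cc1nc(-c2ccccc2)c(C(=O)N2CCN(c3cccc(Cl)c3)CC2)o1` differs from compound 3 in one place: 3-chlorophenyl in place of 2-(trifluoromethyl)phenyl on an amine nitrogen in a ring. Among the measured compounds shown here, the only measured aryl group bearing chlorine belongs to compound 1, whose value sits within the scatter of compound 3, so the step expected is a 1.1-fold lower number from compound 3 to compound 4 (0.04 log units; within the scatter), that is, none beyond the scatter. Compound 4 is therefore estimated at 110 nM in this assay, with a range from 50 nM to 250 nM.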

Compound 4, half-maximal inhibitory concentration: 39.2 nM
Compound 4: the middle estimate sits 2.8-fold (0.45 log units) above what was measured; the measured number lies below the stated range.
By their numbers in this assay, from the lowest: compounds 4 and 2 (each within the scatter of the next); then compounds 3 and 1 (each within the scatter of the next).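

In this assay, the presence of chlorine does not by itself set the level at this position: removing one chloro gives a clear step (a 3.4-fold lower number from compound 1 to compound 4 (0.53 log units; beyond the scatter)), and 3-chlorophenyl in place of 2-(trifluoromethyl)phenyl gives a similar one (a 3.1-fold lower number from compound 3 to compound 4 (0.49 log units; beyond the scatter)). The 3-chlorophenyl group stays level with the 3,4-dimethylphenyl group (a 1.1-fold lower number from compound 2 to compound 4 (0.04 log units; within the scatter)), so two quite different aryl groups share the lower numbers, while compounds 1 and 3 share the higher ones. Nothing measured here accounts for these steps.

From the compounds shown here alone, it remains open how a methoxy group or a nitrile on the aryl ring would behave. Going by these compounds, a pyridine ring in place of that aryl ring is equally open.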